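Removing the arylmethyl group from a piperazine 5-HT1B ligand

This account rests on a few compounds, and the source may have more. Where it says the series, first, only, none or still open, it means among the compounds named here.

Measured compounds:
compound 1 `c1ccc(CN2CCN(CCCc3c[nH]c4ccc(-n5cnnc5)cc34)CC2)nc1`, 18 nM
compound 2 `c1c[nH]c(CN2CCN(CCCc3c[nH]c4ccc(-n5cnnc5)cc34)CC2)n1`, 36 nM

In an assay on CHO cells for displacement of a labelled ligand from 5-hydroxytryptamine receptor 1B (Homo sapiens) (on this read-out lower numbers stand for stronger inhibition and higher numbers for weaker inhibition), compound 1 gives 18 nM, and compound 2 gives 36 nM; the two numbers sit within the scatter of each other, as the step of a 2.0-fold higher number from compound 1 to compound 2 (0.30 log units; within the scatter) shows. Compound 3 `c1cc2[nH]cc(CCCN3CCNCC3)c2cc1-n1cnnc1` differs from compound 2 by hydrogen in place of (1H-imidazol-2-yl)methyl on an amine nitrogen in a ring. Going by the values given here, no measured step bears on this change: the one step recorded swaps one ring for another but keeps the group on the ring nitrogen. The loss of the whole group is therefore expected to weaken binding, a step of a 5.6-fold higher number from compound 2 to compound 3 (0.74 log units; beyond the scatter). Compound 3 is estimated at 200 nM, within 40 nM to 1000 nM.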

Compound 3, half-maximal inhibitory concentration: 145 nM
Compound 3: middle estimate off by 1.4-fold (0.14 log units), on the high side; the range from low to high includes it.
By their numbers in this assay, from the lowest: compounds 1 and 2 (each within the scatter of the next); then compound 3.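

In this assay, hydrogen on the ring nitrogen gives a clear loss against either arylmethyl group, with (a 4.0-fold higher number from compound 2 to compound 3 (0.61 log units; beyond the scatter)) and (an 8.1-fold higher number from compound 1 to compound 3 (0.91 log units; beyond the scatter)), whereas swapping one ring for the other had stayed within the scatter. The group on this amine nitrogen therefore counts for binding, although compound 3 still gives 145 nM without it. No independent evidence accounts for this loss. The compounds shown leave open whether a plain methyl or a benzyl group on that nitrogen would restore binding, and whether a ring is needed there at all.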